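Swapping a Butyl Ether for a Piperidinyl Ether

The source may report more compounds than this note shows. Statements on the series, on what has been measured and on what is new or still open speak of the compounds shown alone.

Measured in a functional assay on MCF7 cells (Homo sapiens) for antiproliferative activity; on this read-out lower numbers stand for stronger inhibition and higher numbers for weaker inhibition:
- compound 1 `CCCCOc1ccc(C(=O)Nc2cc3ccc(OC4CCN(C)CC4)c(C)c3oc2=O)cc1CC=C(C)C`: 1440 nM
- compound 2 `Cc1c(OC2CCN(C)CC2)ccc2cc(NC(=O)c3ccc4c(c3)CCC(C)(C)O4)c(=O)oc12`: 5010 nM
- compound 3 `CC(=O)Oc1ccc(C(=O)Nc2cc3ccc(OC4CCN(C)CC4)c(C)c3oc2=O)cc1Cl`: 1610 nM

Compound 1 stands level with compound 3, within the usual scatter, while compound 2 gives a clearly higher number, which means weaker inhibition. Compound 4 `CC(C)=CCc1cc(C(=O)Nc2cc3ccc(OC4CCN(C)CC4)c(C)c3oc2=O)ccc1OC1CCN(C)CC1` keeps the core of compound 1 but carries 1-methylpiperidin-4-yl in place of butyl on an oxygen on an aromatic ring. For the measured compounds named here, no measured pair shows this change, so the expectation rests only on the narrow spread of the three values. A modest rise in this assay is expected, hardly beyond the scatter, and the estimated step is a 1.7-fold higher number from compound 1 to compound 4 (0.24 log units; within the scatter). For compound 4 the estimate is 2500 nM, with an expected range of 800 nM to 8000 nM.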

Compound 4, half-maximal inhibitory concentration: 470 nM
The estimate for compound 4 lay 5.3-fold (0.73 log units) above the measured number, outside the stated range (below it).
By their numbers in this assay, from the lowest: compound 4; then compounds 1 and 3 (each within the scatter of the next); then compound 2.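

The group on this oxygen clearly matters in this assay and the swap of butyl for 1-methylpiperidin-4-yl gives a 3.1-fold lower number from compound 1 to compound 4 (0.49 log units; beyond the scatter) and so lies beyond the scatter. For the compounds shown here, this is the first pair here that differs in one place only, so the size of a change at this position can now be read. Why the number falls stays unexplained, with no supporting measurement at hand. A single swap cannot separate the part played by the ring from that of its nitrogen. A cyclohexyl group or a dimethylaminoethyl chain on the same oxygen would bear on that question.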